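Swapping the Dichlorophenyl Ring for a Methylphenyl Ring

The source may report more compounds than this note shows. Statements on the series, on what has been measured and on what is new or still open speak of the compounds shown alone.

Of the compounds shown here, three have been measured in a functional assay on CHO-K1 cells for antagonist activity at prostaglandin E2 receptor EP1 subtype (Homo sapiens), read by FLIPR; a higher number here means a weaker inhibitor, a lower number a stronger inhibitor. Compound 1 `O=C(O)c1nn(Cc2cc(Br)ccc2OCc2ccccc2)cc1CO` and compound 2 `O=C(O)c1cn(Cc2cc(Br)ccc2OCc2ccccc2)nn1` each carry a benzyl ether whose outer ring bears no substituent. For compound 1 the assay reports only a limit, < 2000 nM. For compound 2 the assay likewise reports only a limit, < 2000 nM. Going by the values given here, compound 3 `Cc1cc(C(=O)O)nn1Cc1cc(Br)ccc1OCc1ccc(Cl)cc1Cl` differs in its core and in its outer ring, which is a 2,4-dichlorophenyl group; in this assay compound 3 gives 0.49 nM, the only true number among the three, so it stands alone as the one compound with a measured inhibition constant.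

Compound 4 `Cc1cccc(COc2ccc(Br)cc2Cn2nc(C(=O)O)cc2C)c1` keeps everything in compound 3 except that outer ring: 3-methylphenyl in place of 2,4-dichlorophenyl on a saturated chain carbon bound to an oxygen on an aromatic ring. Among the compounds with values here, no step between measured compounds shows how this part of the molecule matters. Two chlorines are replaced by a single methyl, and the step from compound 3 to compound 4 is expected to be a modest loss, a 6.1-fold higher number from compound 3 to compound 4 (0.79 log units; beyond the scatter), though it may well fall within the usual scatter. Compound 4 is therefore expected to give 3 nM, with a range from 0.5 nM to 20 nM.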

Compound 4, inhibition constant: 525 nM
Compound 4: middle estimate off by 180-fold (2.24 log units), on the low side; the measured number lies above the stated range.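

The swap of 2,4-dichlorophenyl for 3-methylphenyl gives a 1100-fold higher number from compound 3 to compound 4 (3.03 log units; beyond the scatter) in this assay, so with the rest of the molecule unchanged, the outer ring on this saturated chain carbon bound to an oxygen on an aromatic ring matters greatly. The two groups have the same counts of hydrogen-bond donors and acceptors, no net charge and one six-membered aromatic ring of carbon only, and these counts do not separate them. Compound 1 and compound 2 differ from compound 4 in more than one place, and their steps cannot be read: the limit of < 2000 nM in this assay, at which 2 of the 4 values shown sit.

This single swap removes two chlorines and adds a methyl, and the compounds shown do not tell which part of it carries the step. From the compounds shown here alone, whether a 3-chlorophenyl or 2,4-dimethylphenyl ring in the same place would stay close to compound 3 remains open.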